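From Pyridin-2-yl to 1,3-thiazol-2-yl: Solubility Outlook

The source may hold more compounds than are shown below. What is called first, only, known or untested is meant among the compounds shown, and "the series" means these compounds.

Of the compounds shown here, three sharing one core have been measured in a physicochemical assay for solubility, in simulated intestinal fluid; a higher number here means a more soluble compound, a lower number a less soluble compound. Compound 1 `COc1ccccc1C(=O)NC(=O)Nc1ccc(N2CCCCC2)c(Cl)c1` gives 8.5 ug/mL. Compound 2 `COc1ccccc1C(=O)NC(=O)Nc1ccc(-c2ccccc2)c(C(C)C)c1` gives 24 ug/mL. Compound 3 `COc1ccccc1C(=O)NC(=O)Nc1ccc(-c2ccccn2)c(C(F)(F)F)c1` gives 8.5 ug/mL. Compound 3 is level with compound 1 at the digits shown, and together they have the lowest numbers of the three; the only number that differs from compound 3 beyond the usual scatter of this assay is that of compound 2, which is higher.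

The next compound, compound 4 `COc1ccccc1C(=O)NC(=O)Nc1ccc(-c2nccs2)c(C(F)(F)F)c1`, is built from compound 3 by a single change: 1,3-thiazol-2-yl in place of pyridin-2-yl on an aromatic carbon. Among the measured compounds there is no pair that differs in exactly this way, so no measured step can guide the outlook; the two rings exchanged are close in size and both aromatic.

The step of a 1.2-fold higher number from compound 3 to compound 4 (0.07 log units; within the scatter) is expected to stay within the scatter, in no clear direction. For compound 4 the estimated value in this assay is 10 ug/mL, with a range from 4 ug/mL to 25 ug/mL.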

Compound 4, solubility: 12 ug/mL
The estimate for compound 4 lay 1.2-fold (0.08 log units) below the measured number; the range from low to high includes it.
By their numbers in this assay, from the lowest: compounds 1, 3, 4 and 2 (each within the scatter of the next, the first and the last beyond it).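

In this assay, among the compounds shown here, putting 1,3-thiazol-2-yl in place of pyridin-2-yl gives a 1.4-fold higher number from compound 3 to compound 4 (0.15 log units; within the scatter) and is the only measured step that changes one place alone. It shows that at this position, ortho to a trifluoromethyl group, a six-membered aromatic ring with one hetero atom and a five-membered aromatic ring with two hetero atoms cannot be told apart by this read-out. No measured property of either ring bears on this result.

As far as these compounds go, whether a different kind of group at this position, such as an open-chain amine or a carboxylic acid, would move the number beyond the scatter remains open. So does whether this ring exchange would read the same with chlorine in place of the trifluoromethyl group.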